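The compounds below may be only part of what the source reports. "The series", "measured", "known", "first", "only" and "open" are said of these compounds alone.

Compound 1 `COc1ccc(C(=O)/C=C/c2ccc([N+](=O)[O-])cc2)c2c1C=CC(C)(C)O2`: 8880 nM
Compound 2 `COc1ccc(C(=O)/C=C/c2ccccc2Cl)c2c1C=CC(C)(C)O2`: > 10000 nM

Both compounds were tested in a functional assay on HCT-116 cells (Homo sapiens) for antiproliferative activity, read by MTT assay, with a stated time of 24 h (on this read-out higher numbers stand for weaker inhibition and lower numbers for stronger inhibition), and they share one core. Compound 1 gives 8880 nM. Compound 2 gives > 10000 nM, which is a limit of the assay and not a number. That leaves compound 2 with no exact position, only (the limit of > 10000 nM in this assay, at which 1 of the 2 values shown sits).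

Compound 3 `COc1ccc(C(=O)/C=C/c2cccc(O)c2)c2c1C=CC(C)(C)O2` carries 3-hydroxyphenyl in place of 2-chlorophenyl, on a double-bonded chain carbon bound to a double-bonded chain carbon: 3-hydroxyphenyl in place of 2-chlorophenyl on a double-bonded chain carbon bound to a double-bonded chain carbon. Among the measured compounds shown here, one measured step bears on this place, an at least 1.1-fold higher number from compound 1 to compound 2 (0.05 log units; that floor lies within the scatter). That step is small and rests on a limit, so it offers little guidance, and no large change is expected in this assay. Compound 3 is expected to remain weak, with an estimated value of 8000 nM and an expected range of 3000 nM to 20000 nM. The expected step is an at least 1.2-fold lower number from compound 2 to compound 3 (0.09 log units; that floor lies within the scatter).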

Compound 3, half-maximal inhibitory concentration: > 10000 nM
Compound 3 gave a limit, no number (the forecaster's own chance of this, stated with the estimate: 45%); middle value at least 1.2-fold (0.09 log units) from the limit.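

In this assay, 3-hydroxyphenyl brings a hydrogen-bond donor and a hydrogen-bond acceptor to this position where 2-chlorophenyl has neither, yet this change produces no readable gain. Among the compounds shown here, the one step that can be read here is an at least 1.1-fold higher number from compound 1 to compound 3 (0.05 log units; that floor lies within the scatter), so it does not separate the 3-hydroxyphenyl and 4-nitrophenyl groups. The step between compound 2 and compound 3 cannot be read because both values are limits, and the same limit now holds most of the values shown: the limit of > 10000 nM in this assay, at which 2 of the 3 values shown sit.

From the compounds shown here alone, how far compound 2 and compound 3 lie past that limit remains open. So does how a phenyl ring bearing an amine or a carboxylic acid at this position would read in this assay.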